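Working notes on a gastric half-maximal-dose series

This account rests on a few compounds, and the source may have more. Where it says the series, first, only, none or still open, it means among the compounds named here.

Measured so far:
compound 1 `C/N=C(/NC#N)NCCCCn1nc(N(C)C)ccc1=O` — > 100 mg/kg
compound 2 `C/N=C(/NC#N)NCCCCn1nc(-c2ccccc2)c(C)cc1=O` — > 100 mg/kg
compound 3 `C=CCNC(=S)NCCCCn1nc(-c2ccccc2)ccc1=O` — > 100 mg/kg

In a functional assay on the whole organism (stomach) with Rattus norvegicus as the target (a lower number here means that less compound is needed, a higher number that more compound is needed for the effect), compound 1 gives > 100 mg/kg, which is a limit of the assay and not a number. Compound 2 and compound 3 likewise return only limits, so all three values sit at the limit of > 100 mg/kg in this assay, at which 3 of the 3 values shown sit, and compound 1 cannot be placed above or below either of them. Compound 4 `C/N=C(/NC#N)NCCCCn1nc(C)ccc1=O` differs from compound 1 by methyl in place of dimethylamino on an aromatic carbon. Within the data shown here, no step between measured compounds is available, and with every value a limit, neither size nor direction can be read; the step from compound 1 to compound 4 is therefore expected to be a step that the limit leaves unreadable from compound 1 to compound 4, nothing beyond the scatter. For compound 4 the estimate is 150 mg/kg, between 50 mg/kg and 400 mg/kg, most probably again reported only as a limit.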

Compound 4, dose for half-maximal effect: > 100 mg/kg
Compound 4: no number, only a limit; the forecaster's own chance of this, stated with the estimate: 75%; the middle value lies beyond the limit too.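

Among these compounds, compound 4 gives > 100 mg/kg, again a limit and not a number, so no step between compound 1 and compound 4 can be read: the limit of > 100 mg/kg in this assay, at which 4 of the 4 values shown sit. The compounds shown leave open whether any change to the shared core gives a numerical value in this assay at all.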